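This account rests on a few compounds, and the source may have more. Where it says the series, first, only, none or still open, it means among the compounds named here.

In an in vitro ADME assay on microsomes (Mus musculus) for metabolic stability (a lower number here means that the compound disappears faster, a higher number that the compound lasts longer), every reading so far is a limit of the assay and not a number. Compound 1 `O=C(Nc1ccccc1)Nc1ccc(-c2nc(N3CC4CCC(C3)O4)c3cnn(C4CCC5(CC4)OCCO5)c3n2)cc1` gives > 0.5 h, which is a limit. Compound 2 `CNC(=O)Nc1ccc(-c2nc(N3CC4CCC(C3)O4)c3cnn([C@H]4CC[C@@H](O)CC4)c3n2)cc1` gives > 0.5 h, also a limit. Compound 3 `CNC(=O)Nc1ccc(-c2nc(N3CC4CCC(C3)O4)c3cnn(C4CCC5(CC4)OCCCO5)c3n2)cc1` gives > 0.5 h, again a limit. Compound 3 therefore stands with the others, at the limit of > 0.5 h in this assay, at which 3 of the 3 values shown sit.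

Compound 4 `CNC(=O)Nc1ccc(-c2nc(N3CC4CCC(C3)O4)c3cnn([C@H]4CC[C@H](O)CC4)c3n2)cc1` differs from compound 3 in one place: a group of 7 heavy atoms (6 carbon, 1 oxygen; one six-membered non-aromatic ring of carbon only) in place of a group of 11 heavy atoms (9 carbon, 2 oxygen; one six-membered non-aromatic ring of carbon only, one six-membered non-aromatic ring with 2 hetero atoms), on an aromatic nitrogen. A 4-hydroxycyclohexyl enters on an aromatic nitrogen, and the larger group with its two six-membered rings leaves. For the measured compounds named here, the only measured step that bears on this exchange is a step that the two limits leave unreadable from compound 2 to compound 3, a change of the same kind running the other way. With its size out of reach, it gives neither a size nor a direction, so nothing beyond the scatter is expected in this assay. The expected change is a step that the limit leaves unreadable from compound 3 to compound 4. Compound 4 is expected at 0.8 h, with an estimated range of 0.5 h to 2 h.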

Compound 4, half-life: > 0.5 h
Compound 4: only a limit was reported (the forecaster's own chance of this, stated with the estimate: 85%); the middle value lies beyond the limit too.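

The steps from compound 3 to compound 4 and from compound 2 to compound 4 cannot be read, since all the readings are the same limit: the limit of > 0.5 h in this assay, at which 4 of the 4 values shown sit. The compounds shown leave open how long any of them actually lasts in this assay, and whether the group on the aromatic nitrogen or its drawn configuration changes that at all.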